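The source may report more compounds than this note shows. Statements on the series, on what has been measured and on what is new or still open speak of the compounds shown alone.

Measured in an ADME assay for permeability, using PAMPA, at pH 7.4; on this read-out higher numbers stand for higher permeability and lower numbers for lower permeability:
- compound 1 `Cc1cc(NC(=O)Nc2ccc(C(C)(C)C)cc2)c2ccccc2n1`: 142 10^-6 cm/s
- compound 2 `Cc1cc(NC(=O)Nc2ccc(C(F)(F)F)cc2)c2ccccc2n1`: 2 10^-6 cm/s

Within the data shown here, compound 2, at 2 10^-6 cm/s, is the lower of the two measured compounds, and compound 1 is its only comparison. The next compound, still unmeasured, is compound 3 `Cc1cc(NC(=O)Nc2ccc(N)cc2)c2ccccc2n1`. It carries amino in place of trifluoromethyl on an aromatic carbon, para to a large group (amino in place of trifluoromethyl on an aromatic carbon).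

Among the measured compounds shown here, only one measured step bears on this change: a 71-fold lower number from compound 1 to compound 2 (1.85 log units; beyond the scatter), a large step with trifluoromethyl in place of tert-butyl on an aromatic carbon. For the measured compounds named here, that step shows how far this assay can move on a single group exchange, but no measured compound carries amino, so it gives no direction here. No step beyond the scatter is expected, and the estimated step is a 1.5-fold higher number from compound 2 to compound 3 (0.18 log units; within the scatter). For compound 3 the estimated value is 3 10^-6 cm/s, with an expected range from 0.5 10^-6 cm/s to 20 10^-6 cm/s.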

Compound 3, apparent permeability: 530 10^-6 cm/s
Beside the measured number, compound 3's estimate is 180-fold (2.25 log units) below it; measured number above the stated range.
By their numbers in this assay, from the lowest: compound 2; then compound 1; then compound 3.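

In this assay, the place para to a large group tolerates a wider span than the earlier pair showed, and the exchange of trifluoromethyl for amino gives a 270-fold higher number from compound 2 to compound 3 (2.42 log units; beyond the scatter), larger than the step between tert-butyl and trifluoromethyl. Amino also surpasses tert-butyl, though by less, with a 3.7-fold higher number from compound 1 to compound 3 (0.57 log units; beyond the scatter), so compound 3 now stands highest of the three, with compound 2 lowest and compound 1 between them. No measurement at hand accounts for this order.

Three groups at one place give an order, not a trend that can be extended to other groups. Going by these compounds, whether methylamino, dimethylamino, hydroxyl or methoxy at this place would stay close to amino or fall toward trifluoromethyl remains open, as does whether the same order holds on another core.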